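The source may report more compounds than this note shows. Statements on the series, on what has been measured and on what is new or still open speak of the compounds shown alone.

Of the compounds shown here, three have so far been measured in an assay on isolated protein for inhibition of Amine oxidase [flavin-containing] A (Homo sapiens), read by fluorescence and spectrophotometry; on this read-out lower numbers stand for stronger inhibition and higher numbers for weaker inhibition. Compound 1 `Cc1cccc(C)c1[Se]CC(C)N` gives 1680 nM, compound 3 `Cc1ccccc1[Se]CC(C)N` gives 5170 nM, and compound 2 `CC(N)C[Te]c1ccccc1` gives 25400 nM, the highest of the three numbers. Among the compounds with values here, the single counted step among them is methyl in place of hydrogen on an aromatic carbon, and it produced a 3.1-fold lower number from compound 3 to compound 1 (0.49 log units; beyond the scatter). Compound 4 `Cc1ccc([Te]CC(C)N)cc1` is not yet measured; it differs from compound 2 by methyl in place of hydrogen on an aromatic carbon. The difference between the core of compound 2 and the core of compound 3 is not broken down here. The change from compound 2 to compound 4 is therefore the same kind of change as that from compound 3 to compound 1, not the same change: the entering methyl in compound 1 is ortho to a group of 5 heavy atoms and meta to a methyl group, whereas in compound 4 it is para to a group of 5 heavy atoms, and the cores are not alike. For compound 4 a step of a 2.1-fold lower number from compound 2 to compound 4 (0.33 log units; beyond the scatter) is expected, resting on the earlier step of a 3.1-fold lower number from compound 3 to compound 1 (0.49 log units; beyond the scatter) but tempered by the different place and core. Compound 4 is thus estimated at 12000 nM, likely between 5000 nM and 30000 nM.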

Compound 4, half-maximal inhibitory concentration: 6660 nM
The estimate for compound 4 lay 1.8-fold (0.26 log units) above the measured number; the measured number falls inside the stated range.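

In this assay, methyl in place of hydrogen on an aromatic carbon, here para to a group of 5 heavy atoms, gives a 3.8-fold lower number from compound 2 to compound 4 (0.58 log units; beyond the scatter). Set beside the earlier step, the change carries over from one core to the other at much the same size: the same change on two cores in this assay, a 3.1-fold lower number (0.49 log units; beyond the scatter) from compound 3 to compound 1 and a 3.8-fold lower number (0.58 log units; beyond the scatter) from compound 2 to compound 4, 1.2-fold (0.09 log units) apart, within the scatter of two such steps. Within the data shown here, this is only one pair on each of two cores, and the methyl enters at a different place in each pair, so the result does not separate the effect of place from that of core, nor does it show that the step would hold on any further core.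

The compounds shown leave open whether an ethyl group, a methoxy group or a chlorine atom on the aromatic ring would give a step like that of methyl. They also leave open how a longer chain, or a secondary amine in place of the primary amine, would behave on either core.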